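Adding a Methoxy Group to Compound 2

The source may report more compounds than this note shows. Statements on the series, on what has been measured and on what is new or still open speak of the compounds shown alone.

Of the compounds shown here, two sharing one core have been measured in a physicochemical assay for solubility, in phosphate buffer, at pH 7.4; a lower number here means a less soluble compound, a higher number a more soluble compound. Compound 1 (`COc1ccccc1C1=NN(c2ccccn2)C(=O)C1`) gives 80900 nM, and compound 2 (`COc1ccc(C2=NN(c3ccccn3)C(=O)C2)cc1`) gives 199000 nM. Compound 2 therefore holds the higher of the two numbers, and its gap to compound 1 lies beyond the usual scatter.

The next structure, compound 3 (`COc1ccc(C2=NN(c3ccccn3)C(=O)C2)cc1OC`), is compound 2 with methoxy in place of hydrogen on an aromatic carbon. The new group sits ortho to a methoxy group and meta to a large group. Among the compounds with values here, no measured pair isolates this change, so the data do not show directly how this assay responds to it. Within the data shown here, since compound 2 at 199000 nM is the higher of only two numbers, a modest fall of about the size of the scatter is the more likely outcome, although no real change remains possible. The expected move is a 1.8-fold lower number from compound 2 to compound 3 (0.26 log units; within the scatter). Compound 3 is estimated at 110000 nM, with an expected range of 40000 nM to 220000 nM.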

Compound 3, solubility: 183000 nM
Estimate against measurement, compound 3: 1.7-fold (0.22 log units) below; low and high end bracket the measured number.
By their numbers in this assay, from the lowest: compound 1; then compounds 3 and 2 (each within the scatter of the next).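

In this assay, methoxy in place of hydrogen on an aromatic carbon, ortho to a methoxy group and meta to a large group, gives a 1.1-fold lower number from compound 2 to compound 3 (0.04 log units; within the scatter). Within the data shown here, this is the first pair to isolate this change, and it shows that at this position compound 2 and compound 3 cannot be told apart in this read-out, so one added methoxy group on this ring produces no step that can be distinguished from repeat measurement. Nothing in the available data accounts for this result.

The compounds shown leave open whether this position would read the same with a different group in place of hydrogen, such as an amine, a carboxylic acid, or a longer chain like butoxy, since methoxy is the only group seen there. Among these compounds, they also leave open whether the same change would give a similar step when made at another aromatic carbon or starting from compound 1, as this single pair speaks only for the one place on compound 2.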